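The source may report more compounds than this note shows. Statements on the series, on what has been measured and on what is new or still open speak of the compounds shown alone.

Measured compounds in a functional assay on A549 cells (Homo sapiens) for antiproliferative activity, read by MTT assay, with a stated time of 48 h; on this read-out lower numbers stand for stronger inhibition and higher numbers for weaker inhibition:
compound 1 `Cc1ccc2c(c1)C1(C(=O)N2C)C(C#N)=C(N)Oc2cc3oc(-c4ccccc4)cc(=O)c3c(O)c21` gives 7060 nM
compound 2 `CN1C(=O)C2(C(C#N)=C(N)Oc3cc4oc(-c5ccccc5)cc(=O)c4c(O)c32)c2cc(Cl)ccc21` gives 4720 nM

Compound 1 stands at the highest number of the two measured in this assay; its nearest neighbour is compound 2, reached by a 1.5-fold lower number from compound 1 to compound 2 (0.17 log units; within the scatter), a step that stays within the scatter, so the two values show no separation of compound 1 from compound 2.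

Compound 3 `Cc1ccc2c(c1)C1(C(=O)N2Cc2ccccc2)C(C#N)=C(N)Oc2cc3oc(-c4ccccc4)cc(=O)c3c(O)c21` has not yet been measured in this assay. It differs from compound 1 by phenyl in place of hydrogen on a saturated chain carbon bound to an amide-type nitrogen in a ring.

Among the compounds with values here, the only measured step, the chloro-for-methyl exchange on an aromatic carbon from compound 1 to compound 2, touches a different part of the shared core and gives no information on substitution at the amide-type nitrogen. Within the data shown here, no measured pair bears on the change from compound 1 to compound 3. On this basis the expected step of a 1.2-fold lower number from compound 1 to compound 3 (0.07 log units; within the scatter) in this assay is none beyond the scatter, with a wide margin in either direction. For compound 3 the estimate in this assay is 6000 nM, expected to lie between 2000 nM and 20000 nM.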

Compound 3, half-maximal inhibitory concentration: > 50000 nM
Compound 3 gave a limit, no number; the forecaster's own chance of this, stated with the estimate: 10%; middle value at least 8.3-fold (0.92 log units) away from the limit.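

In this assay compound 3 gives > 50000 nM, which is a limit of the assay and not a number: the limit of > 50000 nM in this assay, at which 1 of the 3 values shown sits.

Within the data shown here, the change from methyl to benzyl, with phenyl entering on a saturated chain carbon bound to an amide-type nitrogen in a ring, gives an at least 7.0-fold higher number from compound 1 to compound 3 (0.85 log units; beyond the scatter), and this is the first step that lies beyond the scatter, whereas the exchange on the aromatic carbon stays within it at a 1.5-fold lower number from compound 1 to compound 2 (0.17 log units; within the scatter). This position therefore does respond to substitution in this assay, and the change costs antiproliferative activity, though the limit fixes only the smallest possible size of the step and not its true size.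

The compounds shown leave open how the read-out behaves between methyl and benzyl, as an ethyl, a longer chain such as propyl, or a hydrogen at this nitrogen would show. Also open, as far as these compounds go, is whether benzyl in place of methyl on compound 2 brings a step of the same kind, and whether a benzyl group carrying a methoxy or a carboxylic acid on its phenyl ring would behave as the plain benzyl of compound 3 does.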